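Propylamino for 3-Methylpiperazin-1-yl on a Shared Core

This account rests on a few compounds, and the source may have more. Where it says the series, first, only, none or still open, it means among the compounds named here.

Measured compounds:
compound 1, `CCCNc1nc(NCc2ccc(C(=O)NCc3ccc(F)cc3)cc2)c2cc(C)ccc2n1`, 4400 nM
compound 2, `Cc1ccc2nc(N3CCNC(C)C3)nc(NCc3ccc(C(=O)NCc4ccc(F)cc4)cc3)c2c1`, 2900 nM
compound 3, `Cc1ccc2nc(N3CCNC(C)C3)nc(NCc3ccc(C(=O)NC4CCN(Cc5ccc(F)cc5)CC4)cc3)c2c1`, 2000 nM

The three were tested in a functional assay on HCT-116 cells (Homo sapiens) for inhibition, read by luminescence and resazurin assay, with a stated time of 3 days; on this read-out higher numbers stand for weaker inhibition and lower numbers for stronger inhibition. Compound 1 and compound 2 share one core and differ in a single place: propylamino in place of 3-methylpiperazin-1-yl on an aromatic carbon. That change gave a 1.5-fold higher number from compound 2 to compound 1 (0.18 log units; within the scatter). Compound 3 carries the same 3-methylpiperazin-1-yl as compound 2 but a different amide side; the difference between the two cores is not broken down here. Of the three numbers, compound 3 has the lowest, though its gap to compound 2 is within the scatter.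

Compound 4, `CCCNc1nc(NCc2ccc(C(=O)NC3CCN(Cc4ccc(F)cc4)CC3)cc2)c2cc(C)ccc2n1`, is not yet measured. It relates to compound 3 as compound 1 relates to compound 2: propylamino in place of 3-methylpiperazin-1-yl on an aromatic carbon. The place line reads the same word for word, so it is the same change. Because the earlier step was a 1.5-fold higher number from compound 2 to compound 1 (0.18 log units; within the scatter), a step of similar size is expected for compound 4, namely a 1.5-fold higher number from compound 3 to compound 4 (0.18 log units; within the scatter). Compound 4 is therefore estimated at 3000 nM, with a likely range of 1500 nM to 6500 nM.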

Compound 4, half-maximal inhibitory concentration: 1600 nM
Beside the measured number, compound 4's estimate is 1.9-fold (0.27 log units) above it, within the range that was stated.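

In this assay, propylamino in place of 3-methylpiperazin-1-yl on the core of compound 3 gave a 1.3-fold lower number from compound 3 to compound 4 (0.10 log units; within the scatter). Set beside the same change on the core of compound 1, this step does not differ from the earlier one by more than repeated measurements would: the same change on two cores in this assay, a 1.5-fold higher number (0.18 log units; within the scatter) from compound 2 to compound 1 and a 1.3-fold lower number (0.10 log units; within the scatter) from compound 3 to compound 4, 1.9-fold (0.28 log units) apart, within the scatter of two such steps. The two pairs therefore give no sign that the core alters the outcome of this change, and the opposite directions of the two steps cannot be read as a real reversal, but two small steps within the scatter cannot show that the change would carry to any further core or rule out a difference too small to see here.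

The compounds shown leave open how a different group on the same aromatic carbon, such as morpholine or a longer chain like butylamino, would read on these two cores. Going by these compounds, all four numbers come from this assay, so whether the change behaves alike on both cores in any other read-out also stays open.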